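The compounds below may be only part of what the source reports. "The series", "measured", "known", "first", "only" and "open" are said of these compounds alone.

Measured so far:
compound 1 `O=C1/C(=C/c2ccc(Cl)cc2)CCC/C1=C\c1ccccc1[N+](=O)[O-]`, 3700 nM
compound 2 `CN(C)c1ccc(/C=C2\CCC/C(=C\c3ccccc3[N+](=O)[O-])C2=O)cc1`, > 400000 nM
compound 3 `O=C1/C(=C/c2ccc(Cl)cc2)CCC/C1=C\c1ccc([N+](=O)[O-])cc1`, 1500 nM

All three were tested in a functional assay on HSC-2 cells (Homo sapiens) for cytotoxicity, with a stated time of 24 h; a lower number here means that less compound is tolerated, a higher number that more compound is tolerated. Compound 1 gives 3700 nM and compound 3 gives 1500 nM; the difference between their two cores is not broken down here. For compound 2 the result is a limit of this assay, > 400000 nM. The change dimethylamino in place of chloro on an aromatic carbon produced an at least 100-fold higher number from compound 1 to compound 2 (2.03 log units; beyond the scatter), a step known only as a lower bound because of the limit of > 400000 nM in this assay, at which 1 of the 3 values shown sits. Compound 4 `CN(C)c1ccc(/C=C2\CCC/C(=C\c3ccc([N+](=O)[O-])cc3)C2=O)cc1` carries the same change on compound 3: dimethylamino in place of chloro on an aromatic carbon. Since compound 3 gives 1500 nM, a step of a 100-fold higher number from compound 3 to compound 4 (2.00 log units; beyond the scatter) is expected, resting on that single earlier step. Compound 4 is therefore estimated at 150000 nM, with a real chance that this assay again reports only a limit.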

Compound 4, half-maximal cytotoxic concentration: 11000 nM
The estimate for compound 4 lay 14-fold (1.13 log units) above the measured number; the whole stated range lies above it.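

Dimethylamino in place of chloro gives a higher number in this assay on both cores, so the direction of the change carries over, while its size does not, with a 7.3-fold higher number from compound 3 to compound 4 (0.87 log units; beyond the scatter) on the second core. Set beside each other, the two steps clearly differ: the same change on two cores in this assay, an at least 100-fold higher number (2.03 log units; beyond the scatter) from compound 1 to compound 2 and a 7.3-fold higher number (0.87 log units; beyond the scatter) from compound 3 to compound 4, at least 14-fold (1.16 log units) apart, beyond the scatter of two such steps.

As far as these compounds go, the step with 4-nitrophenyl in place of 2-nitrophenyl, an at least 36-fold lower number from compound 2 to compound 4 (1.56 log units; beyond the scatter), is also only a bound, resting on a limit and not on a number, so the true gap between the cores stays unknown, and two cores cannot show how the change behaves on a third.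

Open, from the compounds shown here alone, is whether a methoxy group or a plain amino group in place of chloro would follow the same direction. Also open, going by these compounds, is whether such a group would give a step nearer the larger or the smaller one.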